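The source may report more compounds than this note shows. Statements on the series, on what has been measured and on what is new or still open speak of the compounds shown alone.

In an ADME assay on Huh-7 cells (Homo sapiens) for cytotoxicity, read by MTT assay, with a stated time of 72 h (on this read-out lower numbers stand for higher toxicity in this test and higher numbers for lower toxicity in this test), compound 1 `COc1cc(OC)c2c(=O)cc(-c3ccc(OCc4cn(-c5ccccc5Cl)nn4)c(OCc4cn(-c5ccccc5Cl)nn4)c3)oc2c1` reaches only the limit of > 100 ug/mL. Compound 3 `COc1cc(OC)c2c(=O)cc(-c3ccc(OCc4cn(-c5ccc(Cl)cc5)nn4)c(OC)c3)oc2c1` likewise shows only the limit of > 100 ug/mL in this assay. For compound 2 `COc1cc(O)c(C(=O)/C=C/c2ccc(OC)c(OCc3cn(-c4ccc(F)cc4F)nn3)c2)c(OC)c1` the read-out in this assay is also a limit, > 100 ug/mL, not a number, and its standing is told by the limit of > 100 ug/mL in this assay, at which 3 of the 3 values shown sit. Compound 4 `COc1cc(O)c(C(=O)/C=C/c2ccc(OC)c(OCc3cn(-c4ccc(F)cc4Cl)nn3)c2)c(OC)c1` differs from compound 2 by chloro in place of fluoro on an aromatic carbon. For the measured compounds named here, no step between measured compounds is available, so the effect of this change in this assay can only be expected: none beyond the usual scatter, with compound 4 expected to remain at the limit. Compound 4 is therefore expected at 150 ug/mL, between 90 ug/mL and 300 ug/mL. Compound 4 is thus expected to show a step that the limit leaves unreadable from compound 2 to compound 4.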

Compound 4, half-maximal cytotoxic concentration: > 100 ug/mL
Compound 4: no number, only a limit; the forecaster's own chance of this, stated with the estimate: 90%; the middle value does not contradict the limit.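

For the compounds shown here, compound 2 and compound 4 each give only a limit in this assay, and no step between them can be read. The compounds shown leave open whether chloro in place of fluoro on an aromatic carbon changes this read-out at all.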